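Swapping one phenyl group in compound 1

The source may hold more compounds than are shown below. What is called first, only, known or untested is meant among the compounds shown, and "the series" means these compounds.

- compound 1 (`CN1C/C(=C\c2cccc([N+](=O)[O-])c2)C(=O)/C(=C/c2ccccc2F)C1`): 1010 nM
- compound 2 (`CN1C/C(=C\c2ccc(C#N)cc2)C(=O)/C(=C/c2ccccc2F)C1`): 810 nM

In a functional assay on THP-1 cells (Homo sapiens) for cytotoxicity, read by MTT assay, with a stated time of 24 h (on this read-out higher numbers stand for weaker inhibition and lower numbers for stronger inhibition), compound 1 gives 1010 nM and compound 2 gives 810 nM (the two numbers lie within the usual scatter, so neither ranks ahead). Compound 3 (`CN1C/C(=C\c2ccc(Cl)cc2)C(=O)/C(=C/c2cccc([N+](=O)[O-])c2)C1`) differs from compound 1 as follows: 4-chlorophenyl in place of 2-fluorophenyl on a double-bonded chain carbon bound to a double-bonded ring carbon. Within the data shown here, no measured pair shows such a change, so in this assay no step beyond the scatter is expected, in either direction. The estimate expects a 1.1-fold lower number from compound 1 to compound 3 (0.05 log units; within the scatter) (a small step). For compound 3 the estimated value is 900 nM (expected range 350 nM to 2300 nM).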

Compound 3, half-maximal inhibitory concentration: 7870 nM
Beside the measured number, compound 3's estimate is 8.7-fold (0.94 log units) below it, and the stated range ends below it.
By their numbers in this assay, from the lowest: compounds 2 and 1 (each within the scatter of the next); then compound 3.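

In this assay, the group at this position clearly matters: 4-chlorophenyl in place of 2-fluorophenyl gives a 7.8-fold higher number from compound 1 to compound 3 (0.89 log units; beyond the scatter), a step beyond the scatter. Compounds 1 and 2 both carry 2-fluorophenyl, so they could not show this. Nothing measured here gives a reason for the step.

From the compounds shown here alone, the swap changes both the halogen and the number in the group's name, so which of these counts remains open; a 2-chlorophenyl or 4-fluorophenyl group would separate them. Going by these compounds, how an amine on this phenyl ring would fare also remains open.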